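From fluoro to methyl: a clearance estimate

A few compounds are considered here, and "the series" means these few. Any claim that something is new, unique, unknown or untested is made for them only; others in the source may bear on it.

Measured in an in vivo ADME assay on the whole organism (strain BALB/c) for pharmacokinetics, with Mus musculus as the target, read by LC-MS, at a dose of 5 mg/kg by the oral route (on this read-out higher numbers stand for fast clearance and lower numbers for slow clearance), so far:
- compound 1 `COCCNS(=O)(=O)c1ccc(C)c(C#Cc2cc(Cl)ccc2OCC(=O)O)c1` gives 33.3 mL/min/kg
- compound 2 `CS(=O)(=O)c1ccc(Cl)c(C#Cc2cc(Cl)ccc2OCC(=O)O)c1` gives 11.7 mL/min/kg
- compound 3 `CS(=O)(=O)c1ccc(F)c(C#Cc2cc(Cl)ccc2OCC(=O)O)c1` gives 6.67 mL/min/kg

Compound 3, at 6.67 mL/min/kg in this assay, stands clearly under compound 1 and within the usual scatter of compound 2. The next compound to be tested is compound 4 `Cc1ccc(S(C)(=O)=O)cc1C#Cc1cc(Cl)ccc1OCC(=O)O`, which puts methyl in place of fluoro on an aromatic carbon, para to a methylsulfonyl group: methyl in place of fluoro on an aromatic carbon is the whole change.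

Among the measured compounds shown here, only one measured step swaps a single group at this place, a 1.8-fold lower number from compound 2 to compound 3 (0.24 log units; within the scatter), and it stays within the scatter. For the measured compounds named here, no measured step shows this exact swap. Compound 1, at 33.3 mL/min/kg, also carries a methyl there, but it differs from compound 4 elsewhere too, so it is only a loose warning towards higher numbers. The expected change is a 1.8-fold higher number from compound 3 to compound 4 (0.26 log units; within the scatter) and no step beyond the scatter is anticipated. The estimate for compound 4 is 12 mL/min/kg with an expected range from 5.5 mL/min/kg to 27 mL/min/kg in this measurement.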

Compound 4, clearance: 23.3 mL/min/kg
The estimate for compound 4 lay 1.9-fold (0.29 log units) below the measured number; low and high end bracket the measured number.
By their numbers in this assay, from the lowest: compounds 3, 2, 4 and 1 (each within the scatter of the next, the first and the last beyond it).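

Among the compounds shown here, on an aromatic carbon para to a methylsulfonyl group, the group here does matter in this assay: methyl in place of fluoro gives a 3.5-fold higher number from compound 3 to compound 4 (0.54 log units; beyond the scatter) and is the first single-place step to pass the scatter. Chloro cannot be separated from methyl at this place, with a 2.0-fold higher number from compound 2 to compound 4 (0.30 log units; within the scatter) as the printed step, and it could not be separated from fluoro earlier, so only fluoro and methyl stand apart. With methyl on the ring, the change on the sulfonyl sulfur from (2-methoxyethyl)amino to methyl gives a 1.4-fold lower number from compound 1 to compound 4 (0.16 log units; within the scatter) and so does not separate those two compounds.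

No measurement shown here explains the difference between fluoro and methyl. As far as these compounds go, how a methoxy, a nitrile or an amine at this same place would compare with fluoro remains open.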